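Methoxy versus hydroxy on the chloro-substituted phenyl ring

The source may report more compounds than this note shows. Statements on the series, on what has been measured and on what is new or still open speak of the compounds shown alone.

Measured so far:
compound 1 `COc1cc(Cl)cc(-c2nn(-c3cccc(NC(=O)c4cccc(C(F)(F)F)c4)c3)cc2-c2ccncc2)c1`, 70.7%
compound 2 `O=C(Nc1cccc(-n2cc(-c3ccncc3)c(-c3cc(O)cc(Cl)c3)n2)c1)c1cc(C(F)(F)F)cc(C(F)(F)F)c1`, 64.5%

In a functional assay on SK-MEL-5 cells (Homo sapiens) for inhibition, read by sulforhodamine B assay, with a stated time of 48 h, tested at 10 uM (on this read-out lower numbers stand for a stronger effect and higher numbers for a weaker effect at the one concentration tested), compound 1 gives 70.7%. Compound 2 gives 64.5% in this assay; the two numbers sit within the scatter of each other, so no order can be read between them. Compound 3 `COc1cc(Cl)cc(-c2nn(-c3cccc(NC(=O)c4cc(C(F)(F)F)cc(C(F)(F)F)c4)c3)cc2-c2ccncc2)c1` has not been measured. It differs from compound 2 in one place: methyl in place of hydrogen on an oxygen on an aromatic ring. Compound 1 already carries the methoxy group together with a single trifluoromethyl on the benzamide, and its number does not separate from that of compound 2, so the pair gives no sign that the oxygen substituent moves the read-out. The step of a number 3.5 percentage points higher from compound 2 to compound 3 (within the scatter) is therefore expected to stay inside the scatter, without a clear direction. For compound 3 the estimate is 68%, with a range from 50% to 85%.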

Compound 3, a percentage reported as activity, at one concentration (the size of the read-out at that concentration, not a potency): 67.3%
For compound 3 the middle estimate is 0.7 percentage points above the measured one, and the stated range covers the measured number.
By their numbers in this assay, from the lowest: compounds 2, 3 and 1 (each within the scatter of the next).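

In this assay, hydroxy to methoxy on the 3-chloro-5-hydroxyphenyl group can now be read as a single change: a number 2.8 percentage points higher from compound 2 to compound 3 (within the scatter), so methyl in place of hydrogen on this oxygen produces no readable effect when the benzamide substitution is held constant. With the methoxy group held constant, trifluoromethyl in place of hydrogen on an aromatic carbon of the benzamide can also be read alone, as a number 3.4 percentage points lower from compound 1 to compound 3 (within the scatter), and this step likewise does not separate from the scatter. No measurement bearing on either step is available to explain these results.

Going by these compounds, it remains open whether a longer chain on this oxygen, such as an ethyl or a chain ending in an amine, would separate from these numbers. The same question applies to a carboxylic acid on the benzamide in place of trifluoromethyl.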